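The source may hold more compounds than are shown below. What is called first, only, known or untested is meant among the compounds shown, and "the series" means these compounds.

The measured compounds are compound 1 `O=C1OC[C@H](Cc2ccccc2)[C@H]1Cc1cccc(F)c1` with 75000 nM, compound 2 `O=C1OC[C@H](Cc2ccccc2)[C@H]1Cc1ccc(O)cc1` with 88000 nM, and compound 3 `O=C1OC[C@H](Cc2cccc(F)c2)[C@H]1Cc1ccc(Cl)c(Cl)c1` with 14000 nM, all in a functional assay on HL-60 cells (Homo sapiens) for cytotoxicity, read by WST assay, with a stated time of 48 h; on this read-out lower numbers stand for an effect already at smaller amounts and higher numbers for an effect only at larger amounts of compound.

Compound 1 and compound 2 differ in one place: 4-hydroxyphenyl in place of 3-fluorophenyl on a saturated chain carbon bound to a saturated ring carbon. This change gave a 1.2-fold higher number from compound 1 to compound 2 (0.07 log units; within the scatter), a step that falls within the usual scatter of repeated measurements, so the two values cannot be ordered. Compound 3 stands apart from both, with the lowest of the three numbers; compound 1 gives a higher number and compound 2 a higher one still, both differences beyond the scatter. How the core of compound 3 differs from the core of compound 1 is not broken down here.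

Compound 4 `O=C1OC[C@H](Cc2ccc(O)cc2)[C@H]1Cc1ccc(Cl)c(Cl)c1` has not yet been measured in this assay. It is related to compound 3 exactly as compound 2 is related to compound 1: 4-hydroxyphenyl in place of 3-fluorophenyl on a saturated chain carbon bound to a saturated ring carbon. The place is the same in both pairs, so this is the same change applied a second time, now on the core of compound 3.

Within the data shown here, because the earlier instance of this change gave a 1.2-fold higher number from compound 1 to compound 2 (0.07 log units; within the scatter), the step from compound 3 to compound 4 is expected to be small, roughly a 1.2-fold higher number from compound 3 to compound 4 (0.08 log units; within the scatter), resting on that single earlier pair; no other example of the change is known here. Compound 4 is therefore estimated at 17000 nM in this assay, with a range from 7000 nM to 40000 nM.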

Compound 4, half-maximal effective concentration: 37000 nM
For compound 4 the middle estimate is 2.2-fold (0.34 log units) below the measured one; the measured number falls inside the stated range.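

In this assay, the second instance of the change, 4-hydroxyphenyl in place of 3-fluorophenyl on a saturated chain carbon bound to a saturated ring carbon, gave a 2.6-fold higher number from compound 3 to compound 4 (0.42 log units; beyond the scatter), a modest step. Set beside the earlier instance, this step cannot be told apart from it, so as far as these data go, the change carried over from one core to the other with a similar result: the same change on two cores in this assay, a 1.2-fold higher number (0.07 log units; within the scatter) from compound 1 to compound 2 and a 2.6-fold higher number (0.42 log units; beyond the scatter) from compound 3 to compound 4, 2.3-fold (0.35 log units) apart, within the scatter of two such steps. This does not establish a fixed size for the change, since one of the two steps lies within the scatter and the other beyond it, and two pairs on two cores cannot say whether the core has any influence on the step or whether the same would hold on further cores in this series.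

The compounds shown leave open how other groups at this place would compare with 3-fluorophenyl and 4-hydroxyphenyl, for instance an amine, a carboxylic acid or a longer chain in place of the aromatic ring. They also leave open whether the step seen here would recur on any other read-out than this cytotoxicity measurement.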